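The compounds below may be only part of what the source reports. "The series", "measured", "known", "first", "only" and "open" are said of these compounds alone.

Going by the values given here, in a functional assay on RAW264.7 cells (Mus musculus) for inhibition, read by fluorescence, with stated times of 1 h, 24 h and 30 min (a lower number here means a stronger inhibitor, a higher number a weaker inhibitor), compound 2 `O=C(/C=C/c1ccccc1OC(F)(F)F)c1cccc(O)c1` gives 1610 nM, the only true number available so far. Compound 1 `O=C(/C=C/c1ccccc1F)c1ccc(O)cc1`, which carries a 4-hydroxyphenyl group on its carbonyl carbon, gives > 10000 nM, and this value is a limit of the assay rather than a number. Compound 3 `O=C(/C=C/c1ccccc1OC(F)(F)F)c1ccc(O)cc1` has the same atoms as compound 2, joined differently: 4-hydroxyphenyl in place of 3-hydroxyphenyl on a carbonyl carbon. In words, 4-hydroxyphenyl stands in place of 3-hydroxyphenyl on a carbonyl carbon. Among the compounds with values here, no measured pair of compounds shows this change on its own, so its size can only be estimated. Within the data shown here, the only guide to direction is compound 1, with its limit of > 10000 nM, which suggests a weaker inhibitor and a higher number. The expected change is a 2.5-fold higher number from compound 2 to compound 3 (0.40 log units; beyond the scatter), a moderate weakening beyond the usual scatter. For compound 3 the estimated value is 4000 nM, with an expected range from 1200 nM to 10000 nM.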

Compound 3, half-maximal inhibitory concentration: 1340 nM
For compound 3 the middle estimate is 3.0-fold (0.47 log units) above the measured one; low and high end bracket the measured number.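

In this assay, 4-hydroxyphenyl in place of 3-hydroxyphenyl on a carbonyl carbon gives a 1.2-fold lower number from compound 2 to compound 3 (0.08 log units; within the scatter), so with trifluoromethoxy present this swap shows no readable effect. The weak reading of compound 1 therefore cannot be pinned on its 4-hydroxyphenyl group, which compound 3 also carries; the one place where they differ is trifluoromethoxy in place of fluoro on an aromatic carbon, which gives an at least 7.4-fold lower number from compound 1 to compound 3 (0.87 log units; beyond the scatter). That step sets only a minimum size, since the reading for compound 1 is a limit of the assay and not a number: the limit of > 10000 nM in this assay, at which 1 of the 3 values shown sits.

On these data alone, the true size of the gap between fluoro and trifluoromethoxy stays open, as does whether 3-hydroxyphenyl and 4-hydroxyphenyl also match when fluoro is present. As far as these compounds go, how an aminophenyl group or a phenyl group carrying a carboxylic acid would read on the carbonyl carbon also remains open.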